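Carboxylic acid amides on the shared core: oral inhibition

The source may hold more compounds than are shown below. What is called first, only, known or untested is meant among the compounds shown, and "the series" means these compounds.

Measured compounds:
compound 1, `COc1cccc([C@H]2O[C@H](CC(=O)N3CCC(CC(=O)O)CC3)C(=O)N(CC(C)(C)COCC(=O)OC(C)(C)C)c3ccc(Cl)cc32)c1OC`: 43%
compound 2, `COc1cccc([C@H]2O[C@H](CC(=O)N(C)CC(=O)O)C(=O)N(CC(C)(C)CO)c3ccc(Cl)cc32)c1OC`: -1%
compound 3, `COc1cccc([C@H]2O[C@H](CC(=O)N3CCC(CC(=O)O)CC3)C(=O)N(CC(C)(C)COC(C)=O)c3ccc(Cl)cc32)c1OC`: 81%

In a functional assay on the whole organism for inhibition, with Rattus norvegicus as the target, at a dose of 10 mg/kg by the oral route (a lower number here means less inhibition, a higher number more inhibition at the dose given (going by the name of the read-out)), compound 2 gives -1%, the lowest of the three numbers; compound 1 stands higher at 43%, and compound 3 higher still at 81%. Compound 2 differs from compound 1 and from compound 3 in two places at once, so their values only show that compound 2 sits well below both.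

For the measured compounds named here, the one measured single-point step, a number 38 percentage points higher from compound 1 to compound 3 (beyond the scatter), concerns the cap on the oxygen on the saturated carbon and says nothing about the amide acid, which is where compound 4, `COc1cccc([C@H]2O[C@H](CC(=O)NCCC(=O)O)C(=O)N(CC(C)(C)CO)c3ccc(Cl)cc32)c1OC`, departs from compound 2: (2-carboxyethyl)amino in place of (carboxymethyl)(methyl)amino on a carbonyl carbon on a carbonyl carbon whose other neighbours are a saturated chain carbon. Going by the values given here, no measured pair shows this rearrangement of the same atoms, so the expectation rests on compound 2 alone, with the measured examples only indicating that this series can reach high inhibition when the amide part is altered. Compound 4 is expected to move by a number 16 percentage points higher from compound 2 to compound 4 (beyond the scatter) in this assay, a small rise that may not exceed the scatter. The estimate for compound 4 is 15%, within -10% to 45%.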

Compound 4, a percentage reported as inhibition, in the whole organism at one dose (the size of the read-out at that dose, not a potency): 19%
Compound 4: middle estimate off by 4 percentage points, on the low side, within the range that was stated.
By their numbers in this assay, from the lowest: compound 2; then compound 4; then compound 1; then compound 3.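

In this assay, for the compounds shown here, the step at the carbonyl carbon whose other neighbour is a saturated chain carbon gives a number 20 percentage points higher from compound 2 to compound 4 (beyond the scatter), the first measured single change in the amide acid part of the series. Since (carboxymethyl)(methyl)amino and (2-carboxyethyl)amino hold the same heavy atoms, the read-out responds to how those atoms are joined here and not only to which atoms are present, although this one step bundles the loss of the methyl on nitrogen with the longer chain to the carboxylic acid. No supporting measurement bears on why the number rises.

Still open, from the compounds shown here alone, is which of those two features carries the step: (carboxymethyl)amino or (2-carboxyethyl)(methyl)amino on the same carbonyl carbon would separate them. Going by these compounds alone, equally open is whether the (2-carboxyethyl)amino step holds when the free hydroxyl of compound 4 is replaced by an acetyl ester, the cap found on the oxygen in the higher-reading member of the only other measured single-change pair.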